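Iodo to thiophen-2-yl on a nucleoside core

The source may report more compounds than this note shows. Statements on the series, on what has been measured and on what is new or still open speak of the compounds shown alone.

Compound 1 `COc1nc(N)nc2c1c(-c1cc3ccccc3o1)cn2[C@@H]1O[C@H](CO)[C@@H](O)[C@H]1O`: 16700 nM
Compound 2 `COc1ncnc2c1c(I)cn2[C@@H]1O[C@H](CO)[C@@H](O)[C@H]1O`: > 20000 nM
Compound 3 `Nc1nc2c(c(-c3ccccc3)cn2[C@@H]2O[C@H](CO)[C@@H](O)[C@H]2O)c(=O)[nH]1`: > 20000 nM

Of the compounds shown here, three have been tested in a functional assay on CEM-DNR-bulk cells (Homo sapiens), read by MTT assay, with a stated time of 72 h; on this read-out lower numbers stand for stronger inhibition and higher numbers for weaker inhibition. Compound 1 gives 16700 nM, a number rather than a limit. For compound 2 the result is a limit of the assay, > 20000 nM, and not a number. For compound 3 the result is likewise a limit, > 20000 nM. Compound 2 therefore stands with the weaker side of what has been measured, at the limit of > 20000 nM in this assay, at which 2 of the 3 values shown sit, so its true value is not known beyond that boundary.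

Compound 4 `COc1ncnc2c1c(-c1cccs1)cn2[C@@H]1O[C@H](CO)[C@@H](O)[C@H]1O` has not been measured yet. Its change from compound 2 is thiophen-2-yl in place of iodo on an aromatic carbon. Among the measured compounds shown here, no pair of measured compounds differs in one place, so there is no measured step to lean on. Compound 1, which carries a larger aromatic group at the same kind of position, gives 16700 nM, a measured number. From this a small step of an at least 1.3-fold lower number from compound 2 to compound 4 (0.12 log units; that floor lies within the scatter) toward stronger inhibition is expected, though it may stay within the scatter or at the limit. Compound 4 is estimated at 15000 nM, with a range from 5000 nM to 30000 nM.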

Compound 4, half-maximal inhibitory concentration: 12100 nM
Beside the measured number, compound 4's estimate is 1.2-fold (0.09 log units) above it; low and high end bracket the measured number.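

Among the compounds shown here, with compound 4 the set gains its only pair that differs in one place, and in this assay that pair gives a step: an at least 1.6-fold lower number from compound 2 to compound 4 (0.21 log units; that floor lies within the scatter). For compound 2 the value > 20000 nM is a limit of the assay and not a number. On this aromatic carbon, then, iodo can be replaced by thiophen-2-yl, a larger group with a ring of its own, and the result is a measured number for compound 4 rather than a limit, though the true size of the step cannot be read, as it starts from a limit and its floor stays within the usual scatter: the limit of > 20000 nM in this assay, at which 2 of the 4 values shown sit.

Going by these compounds, one step on one core is no pattern, so it remains open whether any aromatic ring on this carbon would give a similar number, or whether something particular to thiophen-2-yl is involved. Also open, on these data alone, is what quite different groups in the same place would do, such as a small methyl, an amine or a carboxylic acid, and whether any of them would bring the number down clearly beyond the scatter.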